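This account rests on a few compounds, and the source may have more. Where it says the series, first, only, none or still open, it means among the compounds named here.

Measured so far:
Compound 1, `COc1ccc(C)cc1N1C(=O)CSC1c1cccc(C(=O)NCCCCc2ccccc2)c1`: 79%
Compound 2, `O=C(NCCCCc1ccccc1)c1cccc(C2SCC(=O)N2c2ccccc2)c1`: 73%

Both compounds were tested in a functional assay on SJSA-1 cells (Homo sapiens) for inhibition, read by CCK-8 assay, with a stated time of 72 h, tested at 1 uM; a higher number here means more inhibition at the concentration tested (going by the name of the read-out), a lower number less inhibition. Compound 2 has the lower of the two numbers, but the gap to compound 1 is small: the step of a number 6 percentage points lower from compound 1 to compound 2 (within the scatter) lies within the scatter, so the two cannot be told apart on these values.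

Compound 3, `O=C(NCCCCc1ccccc1)c1cccc(C2SCC(=O)N2c2ccccc2F)c1`, has not been measured yet. It differs from compound 2 in one place: fluoro in place of hydrogen on an aromatic carbon. Among the measured compounds shown here, the only measured step that bears on this is the one from compound 1 to compound 2, which also changed the ring on the amide-type nitrogen, swapping a phenyl in for a 2-methoxy-5-methylphenyl, and that larger swap moved the number only within the scatter. A single fluoro on the same ring is a smaller change, so no step beyond the scatter is expected in this assay in either direction.

Compound 3 is therefore estimated at about 72%, with a likely range from 58% to 84%. This estimate means a step of a number 1 percentage points lower from compound 2 to compound 3 (within the scatter), within the scatter.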

Compound 3, a percentage reported as inhibition, at one concentration (the size of the read-out at that concentration, not a potency): 80%
For compound 3 the middle estimate is 8 percentage points below the measured one; the measured number falls inside the stated range.
By their numbers in this assay, from the lowest: compounds 2, 1 and 3 (each within the scatter of the next).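

In this assay, adding a fluoro ortho to a large group on the phenyl ring gives a number 7 percentage points higher from compound 2 to compound 3 (within the scatter), so this single-atom change leaves the number indistinguishable from that of the unsubstituted ring. Changing the ring on the amide-type nitrogen from 2-methoxy-5-methylphenyl to 2-fluorophenyl gives a number 1 percentage points higher from compound 1 to compound 3 (within the scatter), which adds a second comparison that stays within the scatter. This ring has now carried three different substitution patterns across compounds 1, 2 and 3 with no step beyond the scatter, though no measurement is available that could explain this.

The compounds shown leave open whether a very different group on this ring, such as an amine or a carboxylic acid, would move the number beyond the scatter. They also leave open what a longer chain on the amide at the other end of the shared core would do, and the readings at a single concentration do not give the potency of any of the three compounds.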